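The compounds below may be only part of what the source reports. "The series", "measured", "known", "first", "only" and "open" are said of these compounds alone.

In a functional assay on SMMC-7721 cells (Homo sapiens) for inhibition, read by CCK-8 assay, with a stated time of 72 h, tested at 8 uM (on this read-out lower numbers stand for less inhibition of growth and higher numbers for more inhibition of growth at the one concentration tested), three compounds sharing one core have been measured, and they differ only in the group on the sulfur. Compound 1 (`COc1ccc(SCc2ccc(/C=C/C(=O)Nc3ccccc3N)cc2)cc1OC`) gives 44.6%, compound 2 (`Cc1ccc(SCc2ccc(/C=C/C(=O)Nc3ccccc3N)cc2)cc1`) gives 22.2%, and compound 3 (`Nc1ccccc1NC(=O)/C=C/c1ccc(CSc2cccc3ccccc23)cc1`) gives 18.3%. Compound 3 thus stands level with compound 2 and well short of compound 1: the data show a number 3.9 percentage points lower from compound 2 to compound 3 (within the scatter), but also a number 26.3 percentage points lower from compound 1 to compound 3 (beyond the scatter).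

The next compound, compound 4 (`CC(C)(C)c1ccc(SCc2ccc(/C=C/C(=O)Nc3ccccc3N)cc2)cc1`), carries the change (4-(tert-butyl)phenyl in place of naphthalen-1-yl on a sulfur). The step that bears most directly on this is a number 3.9 percentage points lower from compound 2 to compound 3 (within the scatter), where naphthalen-1-yl also enters or leaves against a single substituted phenyl group. The larger steps, a number 22.4 percentage points lower from compound 1 to compound 2 (beyond the scatter) and a number 26.3 percentage points lower from compound 1 to compound 3 (beyond the scatter), both start from the group of compound 1, which plays no part in this change. The expected result is therefore no step beyond the scatter, and the estimated step is a number 4.7 percentage points higher from compound 3 to compound 4 (within the scatter). Compound 4 is expected at 23%, with an estimated range of 9% to 40%.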

Compound 4, percent growth inhibition at one concentration: 23.6%
Compound 4: middle estimate off by 0.6 percentage points, on the low side; measured number inside the range.
By their numbers in this assay, from the lowest: compounds 3, 2 and 4 (each within the scatter of the next); then compound 1.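

In this assay, 4-(tert-butyl)phenyl and naphthalen-1-yl on the sulfur have the same count of 10 heavy atoms but differ in their number of aromatic rings, and the data show a number 5.3 percentage points higher from compound 3 to compound 4 (within the scatter); tert-butyl in place of methyl on an aromatic carbon gives a number 1.4 percentage points higher from compound 2 to compound 4 (within the scatter). Compounds 2, 3 and 4 therefore cannot be told apart, despite their different groups on the sulfur, while a number 21 percentage points lower from compound 1 to compound 4 (beyond the scatter) leaves the 3,4-dimethoxyphenyl group of compound 1 as the only one of the four that stands apart. Nothing measured here explains this result.

The compounds shown leave open whether a single methoxy group on the phenyl ring would stand with compound 1 or with the other three. The same question remains for a hydroxyl group, an amine or a carboxylic acid at that ring.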